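This account rests on a few compounds, and the source may have more. Where it says the series, first, only, none or still open, it means among the compounds named here.

In a functional assay on HOP-62 cells (Homo sapiens) for inhibition, read by sulforhodamine B assay (on this read-out higher numbers stand for weaker inhibition of growth and lower numbers for stronger inhibition of growth), compound 1 `Oc1cccc2[nH]c(-c3ccc(-c4ccc(-c5ccccc5)cc4)cc3)nc12` gives 9040 nM, compound 2 `Oc1ccc(-c2ccc(-c3ccc(-c4nc5c(O)cccc5[nH]4)cc3)cc2)cc1` gives 2410 nM and compound 3 `COc1ccc(-c2ccc(-c3ccc(-c4nc5c(O)cccc5[nH]4)cc3)cc2)cc1` gives 3210 nM. Compound 3 therefore stands level with compound 2, the gap being a 1.3-fold higher number from compound 2 to compound 3 (0.12 log units; within the scatter), and clearly apart from compound 1, as a 2.8-fold lower number from compound 1 to compound 3 (0.45 log units; beyond the scatter) shows.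

The next change leads to compound 4 `CN(C)c1ccc(-c2ccc(-c3ccc(-c4nc5c(O)cccc5[nH]4)cc3)cc2)cc1`, with dimethylamino in place of methoxy on an aromatic carbon, para to a large group (dimethylamino in place of methoxy on an aromatic carbon). Among the measured compounds shown here, no measured step makes this exact exchange. Two modest steps replace hydrogen with a group: a 3.8-fold lower number from compound 1 to compound 2 (0.57 log units; beyond the scatter) for hydroxy and a 2.8-fold lower number from compound 1 to compound 3 (0.45 log units; beyond the scatter) for methoxy. These suggest that compound 2 and compound 3 are better references for compound 4 than compound 1, as compound 4 also carries a group at this place. The closest comparison is the exchange of one group for another at that place, which gave a 1.3-fold higher number from compound 2 to compound 3 (0.12 log units; within the scatter). For the measured compounds named here, with only this one such exchange available, and no dimethylamino example measured, the range stays wide on both sides.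

The estimated change is a 1.1-fold lower number from compound 3 to compound 4 (0.03 log units; within the scatter), so no step beyond the scatter is expected. For compound 4 the expected value is 3000 nM, with an estimated range from 1400 nM to 6500 nM.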

Compound 4, concentration for 50% growth inhibition: 8250 nM
Estimate against measurement, compound 4: 2.8-fold (0.44 log units) below, outside the stated range (above it).
By their numbers in this assay, from the lowest: compounds 2 and 3 (each within the scatter of the next); then compounds 4 and 1 (each within the scatter of the next).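

In this assay, among the compounds shown here, the choice of group at this place on the outer aromatic ring now matters: dimethylamino in place of methoxy gives a 2.6-fold higher number from compound 3 to compound 4 (0.41 log units; beyond the scatter), and dimethylamino in place of hydroxy gives a 3.4-fold higher number from compound 2 to compound 4 (0.53 log units; beyond the scatter), whereas the only earlier exchange of one group for another, methoxy for hydroxy, gave a 1.3-fold higher number from compound 2 to compound 3 (0.12 log units; within the scatter), within the scatter. The lower numbers seen with hydroxy and methoxy are thus not shared by every group replacing hydrogen here, as dimethylamino in place of hydrogen gives a 1.1-fold lower number from compound 1 to compound 4 (0.04 log units; within the scatter), also within the scatter. No measured evidence accompanies these compounds that would account for the difference between dimethylamino and the two oxygen-linked groups.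

The compounds shown leave open whether a primary amine or an ethoxy group at this place would track with dimethylamino or with hydroxy and methoxy, which would help show whether the nitrogen or the oxygen link separates these results. They also leave open how a carboxylic acid or a fluorine atom at this place would compare with hydrogen.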